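The source may hold more compounds than are shown below. What is called first, only, known or untested is meant among the compounds shown, and "the series" means these compounds.

Working notes on the series in a functional assay on the whole organism for inhibition, with Rattus norvegicus as the target, read by paw edema, with stated times of 30 min and 2 h, at a dose of 10 mg/kg by the oral route; on this read-out higher numbers stand for more inhibition at the one dose given (going by the name of the read-out) and lower numbers for less inhibition.

Two compounds have been run. Compound 1 `COc1ccc(C2CC(C3C(=O)c4ccccc4C3=O)=NC(=O)N2)cc1` gives 21% in this assay; compound 2 `O=C1N=C(C2C(=O)c3ccccc3C2=O)CC(c2ccc([N+](=O)[O-])cc2)N1` gives 26%. Among the measured compounds shown here, the single measured step, nitro in place of methoxy on an aromatic carbon, is a number 5 percentage points higher from compound 1 to compound 2 (within the scatter), so the two numbers cannot be told apart. Compound 2 and compound 1 stand within the scatter of each other.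

Compound 3 `O=C1N=C(C2C(=O)c3ccccc3C2=O)CC(/C=C/c2ccccc2)N1` is the next candidate. Its change from compound 2 is 2-phenylethenyl in place of 4-nitrophenyl on a saturated ring carbon. For the measured compounds named here, only one measured step exists, and it bears on this change only loosely: it alters the group on the same saturated ring carbon of the shared core, but by swapping one aromatic substituent for another, not by replacing the whole 4-nitrophenyl with 2-phenylethenyl. That step stayed within the scatter, and no other comparison is available. On this basis the expectation is a step of a number 4 percentage points lower from compound 2 to compound 3 (within the scatter), with no direction beyond the scatter. Compound 3 is therefore estimated at 22%, within a range from 8% to 38%.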

Compound 3, a percentage reported as inhibition, in the whole organism at one dose (the size of the read-out at that dose, not a potency): 32%
The estimate for compound 3 lay 10 percentage points below the measured number; the measured number falls inside the stated range.
By their numbers in this assay, from the lowest: compounds 1, 2 and 3 (each within the scatter of the next, the first and the last beyond it).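

In this assay, among the compounds shown here, the first step beyond the scatter at this saturated ring carbon, next to the ring nitrogen, is a number 11 percentage points higher from compound 1 to compound 3 (beyond the scatter), whereas the change from 4-nitrophenyl to 2-phenylethenyl is a number 6 percentage points higher from compound 2 to compound 3 (within the scatter). For the compounds shown here, the earlier pair showed only that two substituted phenyl groups could not be told apart; this result shows that the position also accepts a group other than a substituted phenyl attached directly to the ring carbon, and that 2-phenylethenyl can be told apart from 4-methoxyphenyl but not from 4-nitrophenyl. Nothing at hand accounts for this difference, and the size of the step to compound 3 from compound 1 is all that can be stated.

Still open, going by these compounds, is whether the double bond of 2-phenylethenyl matters, which 2-phenylethyl or an unsubstituted phenyl on the same carbon would help to settle alongside the shared core. Also open, on these data alone, is how this position responds to groups without an aromatic ring, such as a short alkyl chain, an amine or a carboxylic acid.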